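Side chain of compound 2: dimethylamino to methyl

This account rests on a few compounds, and the source may have more. Where it says the series, first, only, none or still open, it means among the compounds named here.

Measured so far in a functional assay on OVCAR-8 cells (Homo sapiens) for antiproliferative activity; a lower number here means a stronger inhibitor, a higher number a weaker inhibitor:
- compound 1 `Cn1ncc(Cl)c1-c1cc(C(=O)N[C@@H]2CN[C@H](CCN3CCCCC3)C[C@H]2c2ccc(Cl)c(Cl)c2)oc1Cl` gives 1660 nM
- compound 2 `CN(C)CC[C@@H]1C[C@@H](c2ccc(Cl)c(Cl)c2)[C@H](NC(=O)c2cc(-c3c(Cl)cnn3C)c(Cl)o2)CN1` gives 1510 nM

Among the compounds with values here, compound 2 stands level with compound 1, the only other measured compound. Next comes compound 3 `CCC[C@@H]1C[C@@H](c2ccc(Cl)c(Cl)c2)[C@H](NC(=O)c2cc(-c3c(Cl)cnn3C)c(Cl)o2)CN1` with this change: methyl in place of dimethylamino on a saturated chain carbon, two bonds along the chain from a saturated ring carbon that is, methyl in place of dimethylamino on a saturated chain carbon, two bonds along the chain from a saturated ring carbon. Within the data shown here, one measured step bears on it: a 1.1-fold lower number from compound 1 to compound 2 (0.04 log units; within the scatter) puts dimethylamino in place of piperidin-1-yl. That step stays among amino groups, whereas here methyl enters, so it is only a weak guide. Among the measured compounds shown here, no measured step shows such a replacement, so no direction can be given and the range stays wide. No shift beyond the scatter is expected in this assay and the expected move is a 1.0-fold lower number from compound 2 to compound 3 (0.00 log units; within the scatter) at most a modest one. The estimate for compound 3 is 1500 nM with an expected range from 500 nM to 4500 nM in this assay.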

Compound 3, half-maximal inhibitory concentration: 1620 nM
Estimate against measurement, compound 3: 1.1-fold (0.03 log units) below, within the range that was stated.
By their numbers in this assay, from the lowest: compounds 2, 3 and 1 (each within the scatter of the next).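

In this assay the side-chain amine proves dispensable at this position: the change to methyl gives a 1.1-fold higher number from compound 2 to compound 3 (0.03 log units; within the scatter) and the change from piperidin-1-yl gives a 1.0-fold lower number from compound 1 to compound 3 (0.01 log units; within the scatter). The earlier step stayed among amino groups, whereas these two show that 2-(dimethylamino)ethyl can give way to propyl, on a saturated chain carbon two bonds along the chain from a saturated ring carbon, with no shift beyond the scatter. No measurement on hand explains why this read-out stays level across the three compounds.

On these data alone, it remains open whether a carboxylic acid or a hydroxyl group at the end of this chain would also leave the number level. A longer chain, or a shorter one such as ethyl on the same ring carbon, is equally unsettled.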